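The source may hold more compounds than are shown below. What is called first, only, known or untested is meant among the compounds shown, and "the series" means these compounds.

Measured compounds in the series:

Compound 1, `CCOc1cc(C)c(-c2cccc(COc3ccc(OCC(=O)O)c(F)c3)c2)c(C)c1`: in a functional assay on CHO cells for agonist activity at Free fatty acid receptor 1 (Homo sapiens), read by FLIPR and calcium flux (on this read-out lower numbers stand for an effect already at smaller amounts and higher numbers for an effect only at larger amounts of compound), compound 1 gives 65.9 nM.
Compound 2, `Cc1cc(OCCCO)cc(C)c1-c1cccc(COc2ccc(OCC(=O)O)c(F)c2)c1`: in this assay compound 2 gives 110 nM.

Compound 2 holds the highest of the two numbers so far; its nearest neighbour is compound 1, and the two lie within the scatter of each other, as shown by a 1.7-fold higher number from compound 1 to compound 2 (0.22 log units; within the scatter).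

Compound 3, `CCCOc1cc(C)c(-c2cccc(COc3ccc(OCC(=O)O)c(F)c3)c2)c(C)c1`, has not yet been measured in this assay. It differs from compound 2 in one place: hydrogen in place of hydroxy on a saturated chain carbon, three bonds along the chain from an oxygen on an aromatic ring. Read one bond further out, the change is 3-hydroxypropyl to propyl.

Among the measured compounds shown here, only one measured step bears on this change. Going a 1.7-fold higher number from compound 1 to compound 2 (0.22 log units; within the scatter), the hydroxymethyl entered on the chain without moving the number beyond the scatter. Removing the hydroxy again, as in compound 3, is the related step in the other sense; the chain is left one carbon longer than in compound 1. On this basis no step beyond the scatter is expected in this assay for compound 3, with a lean toward a somewhat lower number, that is a 1.5-fold lower number from compound 2 to compound 3 (0.17 log units; within the scatter). Compound 3 is therefore estimated at 75 nM, within a range of 35 nM to 160 nM.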

Compound 3, half-maximal effective concentration in the Free fatty acid receptor 1 assay: 106 nM
For compound 3 the middle estimate is 1.4-fold (0.15 log units) below the measured one, and the stated range covers the measured number.
By their numbers in the Free fatty acid receptor 1 assay, from the lowest: compounds 1, 3 and 2 (each within the scatter of the next).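

In the Free fatty acid receptor 1 assay, hydrogen in place of hydroxy on this saturated chain carbon is tolerated, with a 1.0-fold lower number from compound 2 to compound 3 (0.02 log units; within the scatter). The other route to the propyl chain of compound 3, methyl in place of hydrogen on the chain of compound 1, also stays inside the noise, with a 1.6-fold higher number from compound 1 to compound 3 (0.21 log units; within the scatter), so the three chains shown cannot be told apart on this read-out. The change is nevertheless not silent at this position, since the hydroxy separates the two compounds in a physicochemical assay for lipophilicity, using the shake flask method, in phosphate buffer, measured as octanol-water partition, with a stated time of 24 h, at pH 7.4, tested at 100 uM (on this read-out higher numbers stand for higher lipophilicity and lower numbers for lower lipophilicity), while leaving them within the scatter of each other in receptor potency: the measured distribution coefficient of compound 2, 2.73, and of compound 3, 3.64, a number 0.91 log units higher (beyond the scatter) In the physicochemical assay compound 2 gives 2.73 and compound 3 gives 3.64.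

From the compounds shown here alone, whether an amine or a carboxylic acid in place of the hydroxy, or a longer chain, would also stay within the scatter in the Free fatty acid receptor 1 assay remains open. Among the compounds shown here, the single pair in the physicochemical assay also leaves open how the distribution coefficient would respond to those groups, and whether any of them would move it without moving the receptor read-out.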